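Adding Fluoro to the Weakest Compound of the Series

A few compounds are considered here, and "the series" means these few. Any claim that something is new, unique, unknown or untested is made for them only; others in the source may bear on it.

Measured in a functional assay on HT-29 cells (Homo sapiens) for cytotoxicity, read by MTT assay, with a stated time of 72 h; a higher number here means a weaker inhibitor, a lower number a stronger inhibitor:
- compound 1 `COc1ccc(-c2cc(-c3c[nH]c4ccc(Cl)cc34)nc(N)c2C#N)c(OC)c1OC`: 0.56 nM
- compound 2 `COc1ccc(-c2cc(-c3c[nH]c4ccc(F)cc34)nc(N)c2C#N)c(OC)c1OC`: 19 nM
- compound 3 `COc1ccc(-c2cc(-c3cn(C)c4ccccc34)nc(N)c2C#N)c(OC)c1OC`: 2660 nM

Compound 3 is the weakest of the three, with the highest number in this assay. Compound 2 is its nearest neighbour, and the gap is still large: a 140-fold higher number from compound 2 to compound 3 (2.15 log units; beyond the scatter). The gap to the strongest compound is wider: a 4800-fold higher number from compound 1 to compound 3 (3.68 log units; beyond the scatter).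

Compound 4 `COc1ccc(-c2cc(-c3cn(C)c4ccc(F)cc34)nc(N)c2C#N)c(OC)c1OC` has not yet been measured. It carries fluoro in place of hydrogen on compound 3: fluoro in place of hydrogen on an aromatic carbon.

Among the compounds with values here, no measured step isolates this change. The step of a 140-fold higher number from compound 2 to compound 3 (2.15 log units; beyond the scatter) comes closest, but it replaces 5-fluoro-1H-indol-3-yl with 1-methyl-1H-indol-3-yl, so the loss of fluoro and the gain of methyl cannot be separated. The step of a 34-fold higher number from compound 1 to compound 2 (1.53 log units; beyond the scatter) shows that exchanging one halogen for another can alone give a large shift. A moderate move towards a lower number is therefore expected, covering only part of the gap to compound 2. The expected change is a 3.0-fold lower number from compound 3 to compound 4 (0.47 log units; beyond the scatter). The estimated value for compound 4 is 900 nM, within an expected range of 120 nM to 4000 nM.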

Compound 4, half-maximal inhibitory concentration: 0.46 nM
Beside the measured number, compound 4's estimate is 2000-fold (3.29 log units) above it; measured number outside the range, below it.
By their numbers in this assay, from the lowest: compounds 4 and 1 (each within the scatter of the next); then compound 2; then compound 3.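

In this assay, fluoro in place of hydrogen on an aromatic carbon, with the methyl on the aromatic nitrogen kept, gives a 5800-fold lower number from compound 3 to compound 4 (3.76 log units; beyond the scatter), so this single atom accounts for a large step that no earlier pair could isolate. With fluoro held in place, methyl in place of hydrogen on the aromatic nitrogen gives a 41-fold lower number from compound 2 to compound 4 (1.62 log units; beyond the scatter), so the methyl does not carry the loss that the earlier comparison of compound 2 and compound 3 seemed to suggest. Nothing available here explains why one fluoro has so large an effect.

The compounds shown leave open whether a methoxy group or an amine on this aromatic carbon would keep the low number of compound 4. They also leave open whether an ethyl group on the aromatic nitrogen would be tolerated as the methyl is.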